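One Halophenyl Exchange, Measured Twice in Breast Cancer Cells

A few compounds are considered here, and "the series" means these few. Any claim that something is new, unique, unknown or untested is made for them only; others in the source may bear on it.

Compound 1 `N#CC1=C(N)Oc2c(c3nc4ccccc4nc3c3ccccc23)C12C(=O)N(Cc1cnnn1-c1ccccc1Cl)c1ccccc12` was tested in a functional assay on MCF7 cells (Homo sapiens) for antiproliferative activity, read by MTT assay, with a stated time of 48 h; a lower number here means a stronger inhibitor, a higher number a weaker inhibitor. In this assay compound 1 reaches only a limit, > 50000 nM. Compound 2 `N#CC1=C(N)Oc2c(c3nc4ccccc4nc3c3ccccc23)C12C(=O)N(Cc1cnnn1-c1cccc(Br)c1)c1ccccc12` carries one change relative to compound 1: 3-bromophenyl in place of 2-chlorophenyl on an aromatic nitrogen. In this assay compound 2 likewise reaches only a limit, > 50000 nM. The record between them is a step that the two limits leave unreadable from compound 1 to compound 2, since both values sit at the limit of > 50000 nM in this assay, at which 2 of the 3 values shown sit.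

Compound 3 `N#CC1=C(N)Oc2c(N)cc3nc4ccccc4nc3c2C12C(=O)N(Cc1cnnn1-c1ccccc1Cl)c1ccccc12` stands on a different core; how its core differs from that of compound 1 is not broken down here. In this assay, among the compounds with values here, compound 3 gives 34400 nM, the only number among the three measured compounds.

Compound 4 `N#CC1=C(N)Oc2c(N)cc3nc4ccccc4nc3c2C12C(=O)N(Cc1cnnn1-c1cccc(Br)c1)c1ccccc12` has not been measured. It differs from compound 3 by 3-bromophenyl in place of 2-chlorophenyl on an aromatic nitrogen, and the place of this change is the same as in the pair of compound 1 and compound 2, so it is the same change made a second time.

Within the data shown here, because the first instance of that change is recorded as a step that the two limits leave unreadable from compound 1 to compound 2, its size cannot be read, and the expectation for compound 4 rests on compound 3 alone. The estimate for compound 4 in this assay is 35000 nM, with an expected range from 15000 nM to 90000 nM. Among the measured compounds shown here, this means an expected step of a 1.0-fold higher number from compound 3 to compound 4 (0.01 log units; within the scatter), close to no change, because compound 3 gives 34400 nM and the only earlier instance of the change left no readable size.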

Compound 4, half-maximal inhibitory concentration: > 50000 nM
Compound 4 ended at the assay's limit; the forecaster's own chance of this, stated with the estimate: 35%; at least 1.4-fold (0.15 log units) between middle value and limit.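

On the second core, the exchange of 2-chlorophenyl for 3-bromophenyl is recorded in this assay as an at least 1.4-fold higher number from compound 3 to compound 4 (0.16 log units; that floor lies within the scatter), a floor and not a measured size, and that floor itself lies within the scatter. Within the data shown here, compound 4 reaches only a limit, the same one reached by compound 1 and compound 2: the limit of > 50000 nM in this assay, at which 3 of the 4 values shown sit. The step on the first core cannot be read, so there is no size to carry from one core to the other; the result shows only that the 3-bromophenyl compound on the second core gave no number under the limit, and it does not show that the exchange weakens activity or acts alike on both cores.

Among the four compounds, only compound 3 gives a number, 34400 nM, so what the 2-chlorophenyl and 3-bromophenyl groups do on either core remains unresolved. Also open, on these data alone, is whether an amine or a carboxylic acid in place of the halogen on that phenyl ring would give readable values on both cores, which would allow the same exchange to be compared directly.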